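The compounds below may be only part of what the source reports. "The series", "measured", "known", "first", "only" and "open" are said of these compounds alone.

Two compounds of the series have numbers in hand. Compound 1, `CS(=O)(=O)Nc1ccc(Cl)c2c1CCCC2c1c[nH]cn1`, gives in an assay on isolated protein for binding affinity to Alpha-1A adrenergic receptor (Rattus norvegicus), read by radioligand binding (a higher number here means a weaker inhibitor, a lower number a stronger inhibitor), an inhibition constant of 447 nM. Compound 2, `CS(=O)(=O)Nc1cccc2c1CCCC2C1=NCCN1`, gives in this assay an inhibition constant of 457 nM. Compound 1 holds the lower of the two numbers, but the value of compound 2 sits within the scatter of it, so the two are read as alike.

Compound 3, `CS(=O)(=O)Nc1ccc(F)c2c1CCCC2c1c[nH]cn1`, is not yet measured. It differs from compound 1 in one place: fluoro in place of chloro on an aromatic carbon. Within the data shown here, the halogen on that aromatic carbon is the only thing that changes; the methanesulfonamido group and the rest of the core stay as in compound 1.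

Among the measured compounds shown here, no pair measured so far shows what a halogen swap on that carbon does, so the size of the step has to be guessed. A change of one halogen atom for another at a single position is usually a small step. The step from compound 1 to compound 3 is expected to be modest, toward a weaker value, as a 1.7-fold higher number from compound 1 to compound 3 (0.22 log units; within the scatter). For compound 3 the inhibition constant in this assay is estimated at 750 nM, with a range from 250 nM to 2200 nM.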

Compound 3, inhibition constant: 309 nM
Compound 3: middle estimate off by 2.4-fold (0.39 log units), on the high side; low and high end bracket the measured number.
By their numbers in this assay, from the lowest: compounds 3, 1 and 2 (each within the scatter of the next).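

Fluoro in place of chloro on this aromatic carbon, para to a methanesulfonamido group, gives in this assay a 1.4-fold lower number from compound 1 to compound 3 (0.16 log units; within the scatter) and is the first single-place step available in the series. Compound 1 and compound 3 therefore read as alike, and for these two halogens the identity of the atom at this position makes no difference that can be told from the scatter of the assay. No measurement at hand accounts for this result, so the step stands as an observation only.

The step covers only a swap of one halogen for another, so it says nothing about how far this carbon accepts other kinds of group, such as a methoxy group, a nitrile, an amine or a carboxylic acid, all on the otherwise unchanged core of compound 1. Among these compounds, the role of the methanesulfonamido group also stays open, as no single-place step at that group is at hand, and replacing it with an acetamido group or a free amine would be one way to read it.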